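The source may hold more compounds than are shown below. What is called first, only, known or untested is meant among the compounds shown, and "the series" means these compounds.

Going by the values given here, compound 2 `Cc1cc(NC(=O)Nc2ccc(C(N)=O)cc2)c2ccccc2n1` sits at the lower end of the two numbers measured so far. In a physicochemical assay for solubility, at pH 7.4 (a higher number here means a more soluble compound, a lower number a less soluble compound), compound 2 gives 900 nM, while compound 1 `Cc1ccc(NC(=O)Nc2cc(C)nc3ccccc23)cc1` gives 1300 nM; the step of a 1.4-fold lower number from compound 1 to compound 2 (0.16 log units; within the scatter) is the only one measured and lies within the scatter. Compound 3 `Cc1cc(NC(=O)Nc2ccc(SC(F)(F)F)cc2)c2ccccc2n1` differs from compound 2 by (trifluoromethyl)sulfanyl in place of carbamoyl on an aromatic carbon. Among the compounds with values here, no measured step contains (trifluoromethyl)sulfanyl, and the one measured step, carbamoyl in place of methyl, gives little to lean on. Within the data shown here, the estimate for compound 3 in this assay is therefore placed at 300 nM, with a range from 60 nM to 1500 nM, which would mean an expected step of a 3.0-fold lower number from compound 2 to compound 3 (0.48 log units; beyond the scatter), a wide range being kept because the only measured step, a 1.4-fold lower number from compound 1 to compound 2 (0.16 log units; within the scatter), lay within the scatter.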

Compound 3, solubility: 200 nM
Beside the measured number, compound 3's estimate is 1.5-fold (0.18 log units) above it; low and high end bracket the measured number.
By their numbers in this assay, from the lowest: compound 3; then compounds 2 and 1 (each within the scatter of the next).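

In this assay, the group on this aromatic carbon, para to a large group, now shifts the number beyond the scatter: (trifluoromethyl)sulfanyl in place of carbamoyl gives a 4.5-fold lower number from compound 2 to compound 3 (0.65 log units; beyond the scatter), and in place of methyl it gives a 6.5-fold lower number from compound 1 to compound 3 (0.81 log units; beyond the scatter). Going by these compounds alone, the earlier exchange of carbamoyl for methyl stayed within the scatter, so this position does respond to some changes, and compound 3 is the only compound of the three set clearly apart from both others. No independent evidence bears on why the number falls with this change.

The compounds shown do not separate the effect of the larger entering group from that of losing the hydrogen-bond donor of carbamoyl. From the compounds shown here alone, how an amine, a carboxylic acid or a longer chain on this carbon would compare with methyl and carbamoyl also remains open.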